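From 4-methoxyphenyl to 3-fluorophenyl on the shared core

This account rests on a few compounds, and the source may have more. Where it says the series, first, only, none or still open, it means among the compounds named here.

Among the compounds with values here, in an ADME assay on THP-1 cells (Homo sapiens) for cytotoxicity, read by flow cytometry and propidium iodide staining, with a stated time of 72 h (a lower number here means a stronger inhibitor, a higher number a weaker inhibitor), compound 3 (`COc1ccc(-c2oc3ccc(NC(C)=O)cc3c(=O)c2O)cc1`) gives 9000 nM as the only actual number among the three measured compounds. Compound 2 (`COc1ccccc1-c1oc2ccc(NC(C)=O)cc2c(=O)c1O`) gives > 125000 nM and this is a limit of the assay. Compound 1 (`CC(=O)Nc1ccc2oc(-c3cccc(F)c3)cc(=O)c2c1`) also carries 3-fluorophenyl and gives > 125000 nM as another limit of the assay. Compound 4 (`CC(=O)Nc1ccc2oc(-c3cccc(F)c3)c(O)c(=O)c2c1`) has 3-fluorophenyl in place of the 4-methoxyphenyl of compound 3 (3-fluorophenyl in place of 4-methoxyphenyl on an aromatic carbon). Within the data shown here, the one measured step on this carbon is an at least 13-fold lower number from compound 2 to compound 3 (1.14 log units; beyond the scatter) and it shows that the group there can move the number widely. A change beyond the scatter toward a higher number is therefore expected, estimated as a 4.4-fold higher number from compound 3 to compound 4 (0.65 log units; beyond the scatter) in size. For compound 4 the expected value is 40000 nM with an estimated range of 9000 nM to 125000 nM as its likely span.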

Compound 4, half-maximal inhibitory concentration: 36000 nM
For compound 4 the middle estimate is 1.1-fold (0.05 log units) above the measured one, and the stated range covers the measured number.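

In this assay, 3-fluorophenyl on this carbon, ortho to a hydroxy group, gives a second actual number, which makes the change from 4-methoxyphenyl a fully measured step: a 4.0-fold higher number from compound 3 to compound 4 (0.60 log units; beyond the scatter). Compound 4 also stands apart from the 2-methoxyphenyl analogue, with an at least 3.4-fold lower number from compound 2 to compound 4 (0.54 log units; beyond the scatter), and hydroxy in place of hydrogen matters as well, with an at least 3.4-fold lower number from compound 1 to compound 4 (0.54 log units; beyond the scatter). The values of compound 1 and compound 2 are limits and not numbers, and these two steps give only a minimum size: the limit of > 125000 nM in this assay, at which 2 of the 4 values shown sit.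

The step from compound 3 changes both the substituent and its place on the phenyl ring, and the compounds shown do not separate the two. Going by these compounds, how an amine or a carboxylic acid on that phenyl ring would read remains open.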